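Chain extension on the indole nitrogen of the chloroindolyl-oxindole pair

This account rests on a few compounds, and the source may have more. Where it says the series, first, only, none or still open, it means among the compounds named here.

Two compounds have numbers in a functional assay on cells (Cancer cell lines, Homo sapiens) for cytotoxicity, with a stated time of 48 h; a lower number here means a stronger inhibitor of growth, a higher number a weaker inhibitor of growth. Compound 1 `O=C1Nc2ccccc2/C1=C\c1c(Cl)n(Cc2ccccc2)c2ccccc12` gives 70800 nM in this assay. Compound 2 `O=C1/C(=C/c2c(Cl)[nH]c3ccccc23)c2ccccc2N1Cc1ccccc1`, which carries the benzyl group on the oxindole nitrogen instead, gives 77600 nM in this assay; the two values lie within the scatter of each other, so compound 1 holds the lowest number of the two without being separated from compound 2. Compound 3 `O=C1Nc2ccccc2/C1=C\c1c(Cl)n(CCCc2ccccc2)c2ccccc12` differs from compound 1 in one place: phenethyl in place of phenyl on a saturated chain carbon bound to an aromatic nitrogen. Within the data shown here, no measured pair shows what such a change does here. With only compound 1 at 70800 nM as anchor, the step from compound 1 to compound 3 is expected to stay within the scatter or be at most modestly downward, a 1.2-fold lower number from compound 1 to compound 3 (0.07 log units; within the scatter). Compound 3 is expected to give 60000 nM in this assay, with a range from 25000 nM to 150000 nM.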

Compound 3, concentration for total growth inhibition: 67600 nM
Compound 3: middle estimate off by 1.1-fold (0.05 log units), on the low side; measured number inside the range.
By their numbers in this assay, from the lowest: compounds 3, 1 and 2 (each within the scatter of the next).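

Cut one bond further out, the change is benzyl to 3-phenylpropyl, and it gives the first single-place step in the series: in this assay the step reads a 1.0-fold lower number from compound 1 to compound 3 (0.02 log units; within the scatter). On this saturated chain carbon bound to an aromatic nitrogen, phenethyl in place of phenyl therefore leaves the two values unseparated, with the terminal aromatic ring kept and no hydrogen-bond donors or acceptors entering. Nothing available on this series offers an account of this result.

Still open, as far as these compounds go, is whether a group of another kind at the end of this chain, such as an amine or a carboxylic acid, would give a number separated from that of compound 1. Also open, from the compounds shown here alone, is whether a longer chain or a small methyl group at this nitrogen would do so.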